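The compounds below may be only part of what the source reports. "The series", "measured", "known", "first", "only" and "open" are said of these compounds alone.

Values in a functional assay on U-937 cells (Homo sapiens) for antiproliferative activity, read by MTT assay, with a stated time of 24 h (a lower number here means a stronger inhibitor, a higher number a weaker inhibitor), for the measured compounds
compound 1 `CCCCc1oc2ccccc2c1C(=O)c1ccc(OCC(N)=O)cc1` gives 42200 nM
compound 2 `CCCCNC(=O)COc1ccc(C(=O)c2c(CCCC)oc3ccccc23)cc1` gives 22800 nM
compound 3 `CCCCc1oc2ccccc2c1C(=O)c1ccc(OCC(=O)Nc2cccc(OC)c2)cc1` gives 24200 nM

Compound 3 sits within the scatter of both other compounds. The two steps that reach it are a 1.1-fold higher number from compound 2 to compound 3 (0.03 log units; within the scatter) and a 1.7-fold lower number from compound 1 to compound 3 (0.24 log units; within the scatter). No order can be read among the three values, since a 1.9-fold lower number from compound 1 to compound 2 (0.27 log units; within the scatter) also stays inside the scatter.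

The next compound is compound 4 `CCCCc1oc2ccccc2c1C(=O)c1ccc(OCC(=O)NCc2ccccc2)cc1`. Its difference from compound 3 is benzyl in place of 3-methoxyphenyl on an amide-type nitrogen with benzyl in place of 3-methoxyphenyl on an amide-type nitrogen.

All three measured steps bear on this change, as each swaps one group on that same nitrogen. The closest is a 1.1-fold higher number from compound 2 to compound 3 (0.03 log units; within the scatter). It also replaces one substituent on the nitrogen with another. Hydrogen, butyl and 3-methoxyphenyl have so far given values that cannot be told apart in this assay and no benzyl amide has been measured. No step beyond the scatter is therefore expected, and no direction can be assigned. The expected change is a 1.0-fold higher number from compound 3 to compound 4 (0.01 log units; within the scatter) and it would remain within the scatter. The estimated value for compound 4 is 25000 nM (expected range 12000 nM to 50000 nM).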

Compound 4, half-maximal inhibitory concentration: 16300 nM
The estimate for compound 4 lay 1.5-fold (0.19 log units) above the measured number, and the stated range covers the measured number.
By their numbers in this assay, from the lowest: compounds 4, 2, 3 and 1 (each within the scatter of the next, the first and the last beyond it).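

In this assay, for the compounds shown here, benzyl is the first substituent on the amide-type nitrogen to give a step beyond the scatter from the unsubstituted amide, though only a modest one: a 2.6-fold lower number from compound 1 to compound 4 (0.41 log units; beyond the scatter). Butyl and 3-methoxyphenyl did not reach this against the same parent, yet benzyl cannot be separated from either of them, as shown by a 1.5-fold lower number from compound 3 to compound 4 (0.17 log units; within the scatter) and a 1.4-fold lower number from compound 2 to compound 4 (0.15 log units; within the scatter), so the three substituted amides still form a single group with no order among them. The series therefore gives only a small, benzyl-specific separation from the unsubstituted amide, and no measurement at hand accounts for it.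

Still open, as far as these compounds go, is whether a phenethyl group, a longer chain carrying an amine, or a carboxylic acid on this nitrogen would widen the step from compound 1 or leave the values within the same narrow band. Also open, from the compounds shown here alone, is whether the amide hydrogen matters, which a second group on the nitrogen, such as methyl alongside the benzyl, would test with the shared core held constant.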